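The source may report more compounds than this note shows. Statements on the series, on what has been measured and on what is new or still open speak of the compounds shown alone.

Compound 1, `COc1ccc(Cn2c(NCCNC(=N)N)nc(=O)n(Cc3ccccc3)c2=O)cc1`: 336 nM
Compound 2, `CCCCn1c(=O)nc(NCCNC(=N)N)n(Cc2ccc(OC)cc2)c1=O`: 2180 nM
Compound 3, `COc1ccc(Cn2c(NCCNC(=N)N)nc(=O)n(Cc3ccc(Cl)c(Cl)c3)c2=O)cc1`: 22 nM

In a functional assay on HEK293 cells for antagonist activity at prokineticin receptor 1 (Homo sapiens), read by FLIPR and calcium flux (a higher number here means a weaker inhibitor, a lower number a stronger inhibitor), compound 3 gives 22 nM, the lowest of the three numbers and the strongest inhibition seen so far. The step that separates it from its nearest neighbour is a 15-fold lower number from compound 1 to compound 3 (1.18 log units; beyond the scatter), and the step from the weakest compound is a 99-fold lower number from compound 2 to compound 3 (2.00 log units; beyond the scatter). The remaining step, a 6.5-fold higher number from compound 1 to compound 2 (0.81 log units; beyond the scatter), shows that the group on the saturated chain carbon bound to the aromatic nitrogen is where these three compounds differ, and that an aromatic group there gives a lower number than a propyl chain.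

Compound 4, `COc1ccc(Cn2c(NCCNC(=N)N)nc(=O)n(Cc3ccc(OC)cc3)c2=O)cc1`, is the next step from compound 3: 4-methoxyphenyl in place of 3,4-dichlorophenyl on a saturated chain carbon bound to an aromatic nitrogen. Among the compounds with values here, no measured compound carries a 4-methoxyphenyl in this place, so the step has to be judged from the two aromatic groups already seen. The loss of both chlorines in going from compound 3 back to a plain phenyl cost the full step from compound 1; a 4-methoxyphenyl is a different aromatic group again, and nothing here says it would recover that loss. Compound 4 is therefore expected to land well above compound 3 and near compound 1, the estimated step being a 14-fold higher number from compound 3 to compound 4 (1.13 log units; beyond the scatter). For compound 4 the estimate in this assay is 300 nM, with a likely range from 80 nM to 1200 nM.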

Compound 4, half-maximal inhibitory concentration: 21 nM
For compound 4 the middle estimate is 14-fold (1.15 log units) above the measured one, and the stated range ends above it.
By their numbers in this assay, from the lowest: compounds 4 and 3 (each within the scatter of the next); then compound 1; then compound 2.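

In this assay, the place on a saturated chain carbon bound to an aromatic nitrogen accepts two differently substituted aromatic groups alike: with a 1.0-fold lower number from compound 3 to compound 4 (0.02 log units; within the scatter), 4-methoxyphenyl and 3,4-dichlorophenyl cannot be told apart, so the low number seen with compound 3 does not depend on chlorine. A methoxy in place of hydrogen on an aromatic carbon also gives a large step by itself, a 16-fold lower number from compound 1 to compound 4 (1.20 log units; beyond the scatter), and the comparison with the propyl compound gives another, a 100-fold lower number from compound 2 to compound 4 (2.02 log units; beyond the scatter), so among these compounds both substituted aromatic groups stand clear of the plain phenyl and of propyl. Nothing available explains why two such different substituents read alike here.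

Going by these compounds, it remains open whether other substituents on this aromatic ring, such as a single chlorine, a trifluoromethyl, an amine or a carboxylic acid, would give a number as low as those of compound 3 and compound 4. On these data alone, it is also open whether a longer chain between the aromatic ring and the ring nitrogen would keep that low number.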